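The source may hold more compounds than are shown below. What is called first, only, known or untested is meant among the compounds shown, and "the series" means these compounds.

Going by the values given here, in a functional assay on the whole organism (strain Swiss albino) with Mus musculus as the target, in the maximal electroshock model, with a stated time of 0.5 h (a lower number here means that less compound is needed, a higher number that more compound is needed for the effect), compound 2 `COc1cc2c(cc1OC)C(=O)C(CC1CCN(C(=S)Nc3ccc([N+](=O)[O-])cc3)CC1)C2` gives 30 mg/kg, the lowest of the two numbers measured so far. Among the compounds with values here, the only other measured compound is compound 1 `COc1cc2c(cc1OC)C(=O)C(CC1CCN(C(=S)Nc3ccccc3C)CC1)C2`, which in this assay gives 100 mg/kg; the single known step is a 3.3-fold lower number from compound 1 to compound 2 (0.52 log units; beyond the scatter), in which 4-nitrophenyl replaced 2-methylphenyl on an amide-type nitrogen.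

Compound 3 `COc1cc2c(cc1OC)C(=O)C(CC1CCN(C(=S)Nc3ccc(Cl)cc3)CC1)C2` differs from compound 2 in one place: chloro in place of nitro on an aromatic carbon. Within the data shown here, the one measured step bears on it only loosely, since it changed the substituent on the same aromatic ring but at a different site and swapped one group for another altogether, whereas here only the group on the aromatic carbon para to the large group is exchanged, nitro for chloro. Among the measured compounds shown here, no step in the data isolates this exchange. The account therefore expects that the step from compound 2 to compound 3 is no change at the digits printed from compound 2 to compound 3 (within the scatter), that is, no change beyond the scatter, with the uncertainty wide because compound 2 rests on 30 mg/kg alone. Compound 3 is estimated at 30 mg/kg, in a range from 15 mg/kg to 100 mg/kg.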

Compound 3, minimum effective dose in the Mus musculus assay: 30 mg/kg
The estimate for compound 3 equals the measured number at the digits printed; low and high end bracket the measured number.
By their numbers in the Mus musculus assay, from the lowest: compounds 2 and 3 (each within the scatter of the next); then compound 1.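

In the Mus musculus assay, the result shows that this aromatic carbon, para to a large group, tolerates the exchange of nitro for chloro: no change at the digits printed from compound 2 to compound 3 (within the scatter). In the Mus musculus assay, the step from 2-methylphenyl to 4-chlorophenyl also gives a 3.3-fold lower number from compound 1 to compound 3 (0.52 log units; beyond the scatter), so the lower number is not tied to nitro alone. In a physicochemical assay for lipophilicity (a lower number here means a more polar compound, a higher number a more lipophilic compound), compound 2 gives 4.58 and compound 3 gives 5.11, so this exchange raises lipophilicity without moving the number in the Mus musculus assay: the measured partition coefficient of compound 2, 4.58, and of compound 3, 5.11, a number 0.53 log units higher (beyond the scatter)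

The compounds shown leave open whether the site of the substituent or the substituent itself accounts for the step away from 2-methylphenyl, as that group differs from 4-nitrophenyl and 4-chlorophenyl in both. They also leave open whether the number in the Mus musculus assay would hold with an amine or a carboxylic acid on this same aromatic carbon.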